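Series notes: from compound 2 to compound 4

A few compounds are considered here, and "the series" means these few. Any claim that something is new, unique, unknown or untested is made for them only; others in the source may bear on it.

Measured so far in a functional assay on the whole organism (strain Swiss albino) with Mus musculus as the target, with a stated time of 0.5 h; on this read-out higher numbers stand for an effect only at larger amounts of compound and lower numbers for an effect already at smaller amounts:
- compound 1 `COc1cc(/C=N/NC(=O)Nc2cccc3ccccc23)ccc1O` gives 300 mg/kg
- compound 2 `O=C(N/N=C/c1ccc(Br)cc1)Nc1cccc2ccccc12` gives 300 mg/kg
- compound 3 `O=C(N/N=C/c1ccccc1[N+](=O)[O-])Nc1cccc2ccccc12` gives 300 mg/kg

On the numbers shown, compound 2 stands level with compound 1 and compound 3 at the digits reported; the differences between any two of the three lie within the scatter, so no order among them can be read from this assay as it stands. The three measured compounds share one core and differ only in the aryl group on the carbon with a double bond to nitrogen, and that variation has not moved the read-out at all.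

Compound 4 `COc1cccc(/C=N/NC(=O)Nc2cccc3ccccc23)c1` is the next member, not yet measured. Relative to compound 2 the change is 3-methoxyphenyl in place of 4-bromophenyl on a carbon with a double bond to nitrogen. Within the data shown here, no step between measured compounds is available for this pair, so the expectation rests on the flat picture given by compounds 1, 2 and 3: three different aryl groups, one value.

Given that, no step beyond the scatter is expected from compound 2 to compound 4 in this assay, and the estimated step of no change at the digits printed from compound 2 to compound 4 (within the scatter) is accordingly flat. Compound 4 is expected to give about 300 mg/kg, with a range from 100 mg/kg to 600 mg/kg.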

Compound 4, minimum effective dose: 100 mg/kg
Beside the measured number, compound 4's estimate is 3.0-fold (0.48 log units) above it, and the stated range covers the measured number.
By their numbers in this assay, from the lowest: compound 4; then compounds 1, 2 and 3 (each within the scatter of the next).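

In this assay, among these compounds, the aryl group on a carbon with a double bond to nitrogen now shows an effect on the read-out: 3-methoxyphenyl in place of 4-bromophenyl gives a 3.0-fold lower number from compound 2 to compound 4 (0.48 log units; beyond the scatter), the first step beyond the scatter in this short series. Hydrogen in place of hydroxy on an aromatic carbon gives a 3.0-fold lower number from compound 1 to compound 4 (0.48 log units; beyond the scatter), which shows that the methoxy group alone does not set the number, since that group is present on both sides of this step and the lower number appears only once the hydroxy group is gone. Both steps are modest, and no measurement at hand bears on why either one occurs.

Still open, as far as these compounds go, is whether the lower number belongs to the methoxy group itself, or whether an unsubstituted phenyl, an ethoxy group or an amine on the same ring would give a similar value. Also open, from the compounds shown here alone, is whether the step holds with the shared core changed, for example with a longer chain between the carbon with a double bond to nitrogen and the aryl group.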